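A few compounds are considered here, and "the series" means these few. Any claim that something is new, unique, unknown or untested is made for them only; others in the source may bear on it.

Compound 1 `COc1cccc(-c2c(C)n(Cc3ccccc3F)c3nc(C(C)(C)C)c(CN(C)C)n3c2=O)c1` is one of three compounds built on a shared core that have been tested in an assay on isolated protein for binding affinity to Gonadotropin-releasing hormone receptor (Homo sapiens); a higher number here means a weaker inhibitor, a lower number a stronger inhibitor. In this assay compound 1 gives 1700 nM, the highest of the three numbers, so it is the weakest binder among them. Compound 2 `COc1cccc(-c2c(C)n(Cc3ccccc3F)c3nc(C(C)(C)C)c(CN(C)Cc4ccccc4)n3c2=O)c1` gives 72 nM, and compound 3 `COc1cccc(-c2c(C)n(Cc3ccccc3F)c3nc(C(C)(C)C)c(CNCC4CCCCC4)n3c2=O)c1` gives 430 nM.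

Compound 4 `COc1cccc(-c2c(C)n(Cc3ccccc3F)c3nc(C(C)(C)C)c(CNCC4CCCC4)n3c2=O)c1` has not yet been measured in this assay. It differs from compound 1 in one place: (cyclopentylmethyl)amino in place of dimethylamino on a saturated chain carbon bound to an aromatic carbon.

Among the compounds with values here, two measured steps bear on this change. Adding a phenyl on the same saturated chain carbon bound to the amine nitrogen gave a large gain, a 24-fold lower number from compound 1 to compound 2 (1.37 log units; beyond the scatter). Putting (cyclohexylmethyl)amino in place of dimethylamino, the closest relative of the present change, gave a modest gain, a 4.0-fold lower number from compound 1 to compound 3 (0.60 log units; beyond the scatter). Since compound 4 carries a five-membered ring where compound 3 carries a six-membered one, a modest drop in the number, close to that seen for compound 3, is expected, a 3.4-fold lower number from compound 1 to compound 4 (0.53 log units; beyond the scatter). Compound 4 is therefore estimated at 500 nM, with a likely range of 200 nM to 1300 nM.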

Compound 4, inhibition constant: 6400 nM
Estimate against measurement, compound 4: 13-fold (1.11 log units) below, outside the stated range (above it).
By their numbers in this assay, from the lowest: compound 2; then compound 3; then compound 1; then compound 4.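

In this assay this position does not simply reward any larger amine carrying a ring: (cyclopentylmethyl)amino in place of dimethylamino gives a 3.8-fold higher number from compound 1 to compound 4 (0.58 log units; beyond the scatter) and so runs opposite to the cyclohexyl analogue. Ring size alone matters sharply here, as cyclopentyl in place of cyclohexyl gives a 15-fold higher number from compound 3 to compound 4 (1.17 log units; beyond the scatter) even though nothing else changes. Measured against the benzyl(methyl)amino group, the same amine gives an 89-fold higher number from compound 2 to compound 4 (1.95 log units; beyond the scatter) and so sets the widest gap yet seen among groups at this saturated chain carbon.

Nothing available explains why the five-membered ring fares so much worse than the six-membered one. Also open, as far as these compounds go, is whether a cyclobutyl or cycloheptyl ring on the same chain, or a benzylamino group that keeps the amine hydrogen, would track compound 3 or compound 4.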